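This account rests on a few compounds, and the source may have more. Where it says the series, first, only, none or still open, it means among the compounds named here.

In a functional assay on thoracic aorta for antagonist activity at Alpha-1D adrenergic receptor (Rattus norvegicus) (a lower number here means a less potent compound, a higher number a more potent compound, by a factor of ten per unit of this negative logarithm), three compounds have been measured so far:

compound 1, `COc1cccc(OC)c1OCCNCCOc1ccccc1OCc1ccccc1Cl`, gives 8.59;
compound 2, `COc1cccc(OC)c1OCCNCCOc1ccccc1OCc1ccc(C)cc1`, gives 9.12;
compound 3, `COc1cccc(OC)c1OCCNCCOc1ccccc1OCc1ccccc1[N+](=O)[O-]`, gives 8.95.

Compound 3 stands second of the three. Its nearest neighbour is compound 2, and the step of a number 0.17 log units lower from compound 2 to compound 3 (within the scatter) lies within the scatter, so the two cannot be told apart. Its furthest neighbour is compound 1, and the step of a number 0.36 log units higher from compound 1 to compound 3 (beyond the scatter) is a modest gain beyond the scatter.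

Compound 4, `COc1cccc(OC)c1OCCNCCOc1ccccc1OCc1ccc([N+](=O)[O-])cc1`, has not yet been measured. It differs from compound 3 only in the change (4-nitrophenyl in place of 2-nitrophenyl on a saturated chain carbon bound to an oxygen on an aromatic ring), which reads, cut one bond further out, as (2-nitrobenzyl)oxy to (4-nitrobenzyl)oxy; the two compounds have the same atoms, joined differently.

For the measured compounds named here, no measured step moves the nitro group alone. The closest guide is the step of a number 0.53 log units higher from compound 1 to compound 2 (beyond the scatter), which combined a shift from a 2-substituted to a 4-substituted phenyl with a change of group, and the step of a number 0.17 log units lower from compound 2 to compound 3 (within the scatter), which went the other way and stayed within the scatter. Compound 2, with a 4-substituted ring, has the highest number seen, but only one substituent has been tried there. On this basis compound 4 is expected to show a small step, a number 0.15 log units higher from compound 3 to compound 4 (within the scatter), most likely within the scatter and, if anything, upward. The estimate for compound 4 in this assay is 9.1, with a range from 8.6 to 9.6.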

Compound 4, negative logarithm of the antagonist equilibrium constant: 9.41
For compound 4 the middle estimate is 0.31 log units below the measured one; low and high end bracket the measured number.
By their numbers in this assay, from the lowest: compound 1; then compounds 3, 2 and 4 (each within the scatter of the next, the first and the last beyond it).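

In this assay, for the compounds shown here, the pair formed by compound 3 and compound 4 is the first to isolate where the nitro group sits, and 4-nitrophenyl in place of 2-nitrophenyl gives a number 0.46 log units higher from compound 3 to compound 4 (beyond the scatter) with the atoms unchanged, so this rearrangement alone shifts the number by more than the scatter. Exchanging methyl for nitro on the aromatic carbon gives a number 0.29 log units higher from compound 2 to compound 4 (within the scatter) and leaves those two compounds indistinguishable, whereas 4-nitrophenyl in place of 2-chlorophenyl gives a number 0.82 log units higher from compound 1 to compound 4 (beyond the scatter), the widest step in this set. No available evidence explains why moving the nitro group has this effect.

As far as these compounds go, the nitro pair is the only one here that compares 2-nitrophenyl with 4-nitrophenyl directly, so it remains open whether 4-chlorophenyl would stand above 2-chlorophenyl or 4-methylphenyl above 2-methylphenyl in the same way. From the compounds shown here alone, it is also open how 3-nitrophenyl would compare with these two isomers, and whether an amine or a carboxylic acid in place of the nitro group on 4-nitrophenyl would keep the number at this level.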